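From methyl to trifluoromethyl on the shared core

The source may hold more compounds than are shown below. What is called first, only, known or untested is meant among the compounds shown, and "the series" means these compounds.

Values in a functional assay on MCF7 cells (Homo sapiens) for antiproliferative activity, read by MTT assay, with a stated time of 72 h (a lower number here means a stronger inhibitor, a higher number a weaker inhibitor), are these.
- Compound 1 `CNc1nc(-c2cc(OC)c(OC)c(OC)c2)c(-c2ccc(C(F)(F)F)cc2)s1` gives 7290 nM
- Compound 2 `COc1cc(-c2nc(N(C)C)sc2-c2ccc(C(F)(F)F)cc2)cc(OC)c1OC` gives > 10000 nM, which is a limit of the assay
- Compound 3 `COc1cc(-c2nc(C)sc2-c2ccc(C)cc2)cc(OC)c1OC` gives 1740 nM

Compound 3 holds the lower of the two actual numbers, and compound 1 lies above it beyond the scatter. Compound 4 `COc1cc(-c2nc(C)sc2-c2ccc(C(F)(F)F)cc2)cc(OC)c1OC` differs from compound 3 in one group: trifluoromethyl in place of methyl on an aromatic carbon. Among the measured compounds shown here, the only measured step, an at least 1.3-fold higher number from compound 1 to compound 2 (0.13 log units; that floor lies within the scatter), lies on a nitrogen and does not test this change. Compound 1, which carries trifluoromethyl, gives 7290 nM, but it also differs from compound 3 at a second place. A moderate rise in this assay is therefore expected. The expected change is a 2.3-fold higher number from compound 3 to compound 4 (0.36 log units; beyond the scatter). Compound 4 is estimated at 4000 nM, with an expected range from 1200 nM to 10000 nM.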

Compound 4, half-maximal inhibitory concentration: > 10000 nM
Compound 4: only a limit was reported; the forecaster's own chance of this, stated with the estimate: 15%; middle value at least 2.5-fold (0.39 log units) away from the limit.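

In this assay, among the compounds shown here, trifluoromethyl in place of methyl on an aromatic carbon, para to a large group, gives an at least 5.7-fold higher number from compound 3 to compound 4 (0.75 log units; beyond the scatter), the first step that tests this change on its own. At the other changed place, methyl in place of methylamino gives an at least 1.3-fold higher number from compound 1 to compound 4 (0.13 log units; that floor lies within the scatter), a floor that cannot show whether that exchange matters. The step from compound 2 to compound 4 cannot be read, as both values are limits: the limit of > 10000 nM in this assay, at which 2 of the 4 values shown sit. The compounds shown leave open whether a chlorine or a nitrile at this carbon would stay near compound 3 or rise as trifluoromethyl does.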